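Two Inactive Aryl Groups and a Difluorophenyl Successor

The compounds below may be only part of what the source reports. "The series", "measured", "known", "first", "only" and "open" are said of these compounds alone.

The compounds share a core in which an amide links an aryl ether to a six-membered ring bearing two nitrogens, and only the group on the aromatic nitrogen varies. Compound 1, `Cc1cc(=O)n(-c2ccccc2C(F)(F)F)nc1C(=O)Nc1ccc(Oc2ncnc3sccc23)cc1`, carries a 2-(trifluoromethyl)phenyl there. In a functional assay on MCF7 cells (Homo sapiens) for cytotoxicity, read by MTT assay, with a stated time of 72 h (a higher number here means a weaker inhibitor, a lower number a stronger inhibitor), compound 1 gives only a limit, > 40000 nM. Compound 2, `Cc1ccc(-n2nc(C(=O)Nc3ccc(Oc4ncnc5sccc45)cc3)c(C)cc2=O)cc1`, carries a 4-methylphenyl instead. In this assay compound 2 likewise gives only a limit, > 40000 nM. The step that the two limits leave unreadable from compound 1 to compound 2 therefore cannot be read, and compound 2 stands at the edge of what this measurement can report, as the limit of > 40000 nM in this assay, at which 2 of the 2 values shown sit, makes plain.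

Compound 3, `Cc1cc(=O)n(-c2ccc(F)c(F)c2)nc1C(=O)Nc1ccc(Oc2ncnc3sccc23)cc1`, follows the same pattern of exchange: 3,4-difluorophenyl in place of 4-methylphenyl on an aromatic nitrogen. Among the measured compounds shown here, the one measured step at this position is unreadable in size, so there is no basis for expecting a step beyond the scatter in either direction. Compound 3 is expected to sit again at the limit, with the expected step of a number no higher from compound 2 to compound 3 (the limit leaves the size open). Compound 3 is estimated at 40000 nM, ranging from 10000 nM to 160000 nM.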

Compound 3, half-maximal inhibitory concentration: 16100 nM
Compound 3: middle estimate off by 2.5-fold (0.40 log units), on the high side; measured number inside the range.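

Compound 3 gives the series its first reading that is a number rather than a limit, so the group on the aromatic nitrogen can shift the result in this assay: the limit of > 40000 nM in this assay, at which 2 of the 3 values shown sit. Replacing 4-methylphenyl with 3,4-difluorophenyl gives an at least 2.4-fold lower number from compound 2 to compound 3 (0.39 log units; beyond the scatter), and replacing 2-(trifluoromethyl)phenyl with 3,4-difluorophenyl gives an at least 2.4-fold lower number from compound 1 to compound 3 (0.39 log units; beyond the scatter); both sizes are minimums, since the true values of the starting compounds lie somewhere beyond the limit. Fluorine alone does not account for the change, as compound 1 also carries fluorine and still gives only a limit, so compound 1 goes against any simple rule linking fluorine to a measurable reading.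

On these data alone, it remains open whether both fluorines of compound 3 are needed, and how an unsubstituted phenyl, a phenyl with a single fluorine, or a phenyl bearing an amine or a carboxylic acid would read at this position. Among the compounds shown here, with only three compounds, all tested on a single cell line, it is also unknown how far this position can lower the number, or whether the same order would hold in other cells.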